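The compounds below may be only part of what the source reports. "The series", "measured", "known", "first", "only" and "open" are said of these compounds alone.

Of the compounds shown here, three sharing one core have been tested in a functional assay on A549 cells (Homo sapiens) for antiproliferative activity, read by MTT assay, with a stated time of 48 h; a higher number here means a weaker inhibitor of growth, a lower number a stronger inhibitor of growth. Compound 2 `COC(=O)N1N=C(c2cccc(OC)c2)CC1c1cc(OC)c(OC)c(OC)c1` gives 2590 nM, and compound 3 `COC(=O)N1N=C(c2ccc(OC)cc2)CC1c1cc(OC)c(OC)c(OC)c1` gives 3400 nM. The step between them, a 1.3-fold higher number from compound 2 to compound 3 (0.12 log units; within the scatter), does not separate the two, so compound 3 stands level with compound 2. Compound 1 `CCCOC(=O)N1N=C(c2ccccc2)CC1c1cc(OC)c(OC)c(OC)c1` gives > 10000 nM, which is a limit of the assay and not a number.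

Compound 4 `CCCOC(=O)N1N=C(c2ccc(OC)cc2)CC1c1cc(OC)c(OC)c(OC)c1` is compound 3 with one change: ethyl in place of hydrogen on a saturated chain carbon bound to an oxygen next to a carbonyl group, so that methoxycarbonyl becomes propoxycarbonyl. Among the measured compounds shown here, no measured step isolates this change. The swap of 3-methoxyphenyl for 4-methoxyphenyl, a 1.3-fold higher number from compound 2 to compound 3 (0.12 log units; within the scatter), lies at another place on the molecule and gives no size for it. For the measured compounds named here, the only hint comes from compound 1, which also carries propoxycarbonyl and sits at the limit of > 10000 nM in this assay, at which 1 of the 3 values shown sits, though it differs from compound 4 elsewhere as well. That hint is weak, but it points towards weaker growth inhibition, and a result at the limit would be no surprise. The expected change in this assay is modest, with an estimated 1.8-fold higher number from compound 3 to compound 4 (0.25 log units; within the scatter). For compound 4 the estimated value is 6000 nM, with an expected range of 2200 nM to 16000 nM.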

Compound 4, concentration for 50% growth inhibition: > 10000 nM
Compound 4 gave a limit, no number (the forecaster's own chance of this, stated with the estimate: 40%); middle value at least 1.6-fold (0.22 log units) from the limit.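

In this assay, among the compounds shown here, the swap of methoxycarbonyl for propoxycarbonyl, which no earlier pair isolated, now has a direct reading on the shared core: an at least 2.9-fold higher number from compound 3 to compound 4 (0.46 log units; beyond the scatter). The value for compound 4 is a limit of the assay and not a number, so this step gives only a lower bound on the size of the change, but that bound already shows that ethyl in place of hydrogen at this saturated chain carbon weakens growth inhibition when the aryl group is 4-methoxyphenyl. The step from compound 1 to compound 4 cannot be read, so the methoxy group on the aromatic carbon has no measurable effect here, and both compounds with propoxycarbonyl end at the same ceiling: the limit of > 10000 nM in this assay, at which 2 of the 4 values shown sit.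

The compounds shown leave open how much weaker propoxycarbonyl truly is, as neither compound carrying it has a number, and whether the same penalty holds with 3-methoxyphenyl. They also leave open how ethoxycarbonyl would read at this position, and whether a group such as acetyl or a carboxamide would restore the activity seen with methoxycarbonyl.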